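Carboxyphenyl directly on the ring nitrogen

The compounds below may be only part of what the source reports. "The series", "measured", "known", "first", "only" and "open" are said of these compounds alone.

For the measured compounds named here, compound 2 `O=C(O)c1ccc(S(=O)(=O)N2CCC(NS(=O)(=O)c3cc(S(=O)(=O)c4ccccc4)ccc3C(F)(F)F)CC2)cc1` gives 20 nM in an assay on isolated protein for displacement of a labelled ligand from secreted frizzled-related protein 1 (Homo sapiens), read by fluorescence polarization, with a stated time of 30 min (on this read-out higher numbers stand for weaker inhibition and lower numbers for stronger inhibition), the lowest of the two numbers so far; compound 1 `O=C(c1cccc(Cl)c1)N1CCC(NS(=O)(=O)c2cc(S(=O)(=O)c3ccccc3)ccc2C(F)(F)F)CC1` gives 300 nM, and the change from compound 1 to compound 2 brought a 15-fold lower number from compound 1 to compound 2 (1.18 log units; beyond the scatter). Compound 3 `O=C(O)c1ccc(N2CCC(NS(=O)(=O)c3cc(S(=O)(=O)c4ccccc4)ccc3C(F)(F)F)CC2)cc1` differs from compound 2 in one place: 4-carboxyphenyl in place of (4-carboxyphenyl)sulfonyl on an amine nitrogen in a ring. Going by the values given here, no measured step bears directly on this change, since only the whole arm on that nitrogen has been varied. A moderate rise in the number is therefore expected, a 3.0-fold higher number from compound 2 to compound 3 (0.48 log units; beyond the scatter), with wide uncertainty. Compound 3 is estimated at 60 nM, between 15 nM and 250 nM.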

Compound 3, half-maximal inhibitory concentration: 120 nM
Estimate against measurement, compound 3: 2.0-fold (0.30 log units) below, within the range that was stated.
By their numbers in this assay, from the lowest: compound 2; then compound 3; then compound 1.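

In this assay, dropping the sulfonyl so that 4-carboxyphenyl sits on the amine nitrogen in the ring gives back part of the earlier gain (a 6.0-fold higher number from compound 2 to compound 3 (0.78 log units; beyond the scatter)). Even so, this shorter arm still gives a lower number than the (3-chlorophenyl)carbonyl arm (a 2.5-fold lower number from compound 1 to compound 3 (0.40 log units; beyond the scatter)), so the sulfonyl accounts for only part of the advantage of compound 2 over compound 1. Nothing measured here explains either shift. Still open, on these data alone, is how much the carboxylic acid itself contributes. An amide or a methyl ester in its place on either arm would test that.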